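Fluoro-for-Chloro Swap on the Amide-Side Phenyl Ring

This account rests on a few compounds, and the source may have more. Where it says the series, first, only, none or still open, it means among the compounds named here.

Compound 1 `O=C(CSc1nc(Nc2ccccc2)c2ccccc2n1)Nc1ccc(F)cc1` gives > 50000 nM in a functional assay on MGC-803 cells (Homo sapiens) for inhibition, read by MTT assay, with a stated time of 72 h (on this read-out higher numbers stand for weaker inhibition and lower numbers for stronger inhibition), which is a limit of the assay rather than a number.
Compound 2 `O=C(CSc1nc(Nc2ccccc2)c2ccccc2n1)Nc1ccc(Cl)cc1` gives 40400 nM in this assay.
Compound 3 `O=C(CSc1nc(Nc2ccccc2)c2ccccc2n1)Nc1ccc(Cl)c(Cl)c1` gives 37900 nM in this assay.

The three compounds share one core and differ only on the phenyl ring attached to the amide nitrogen. Compound 2 and compound 3 differ by chloro in place of hydrogen on an aromatic carbon, and their values sit within the scatter of each other. From compound 2 to compound 1 the change is fluoro in place of chloro on an aromatic carbon, and it gave an at least 1.2-fold higher number from compound 2 to compound 1 (0.09 log units; that floor lies within the scatter). Compound 1 sits at the limit of > 50000 nM in this assay, at which 1 of the 3 values shown sits.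

Compound 4 `O=C(CSc1nc(Nc2ccccc2)c2ccccc2n1)Nc1ccc(F)c(Cl)c1` is not yet measured. It differs from compound 3 by fluoro in place of chloro on an aromatic carbon, the same kind of change, though here the place is ortho to a chloro group (1 heavy atom), which the earlier pair lacks. Compound 4 is expected to show a 1.5-fold higher number from compound 3 to compound 4 (0.16 log units; within the scatter), resting on compound 3 at 37900 nM and on the earlier step of an at least 1.2-fold higher number from compound 2 to compound 1 (0.09 log units; that floor lies within the scatter). The estimate for compound 4 in this assay is 55000 nM, expected to fall between 30000 nM and 100000 nM, and quite possibly reported only as a limit again.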

Compound 4, half-maximal inhibitory concentration: 20900 nM
For compound 4 the middle estimate is 2.6-fold (0.42 log units) above the measured one; the whole stated range lies above it.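

In this assay, fluoro in place of chloro on the 3,4-dichlorophenyl ring gave a 1.8-fold lower number from compound 3 to compound 4 (0.26 log units; within the scatter), and going from 4-chlorophenyl to 3-chloro-4-fluorophenyl gave a 1.9-fold lower number from compound 2 to compound 4 (0.29 log units; within the scatter), so neither pair is set apart, and the fluoro swap cannot be said to behave differently on the two cores: the same change on two cores in this assay, an at least 1.2-fold higher number (0.09 log units; that floor lies within the scatter) from compound 2 to compound 1 and a 1.8-fold lower number (0.26 log units; within the scatter) from compound 3 to compound 4; the limit leaves it open whether they differ
Chloro in place of hydrogen gave an at least 2.3-fold lower number from compound 1 to compound 4 (0.37 log units; beyond the scatter), the one step here beyond the scatter, but set beside its earlier counterpart it does not show that this change differs in size from one core to the other: the same change on two cores in this assay, a 1.1-fold lower number (0.03 log units; within the scatter) from compound 2 to compound 3 and an at least 2.3-fold lower number (0.37 log units; beyond the scatter) from compound 1 to compound 4; the limit leaves it open whether they differ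
Compound 1 stands only at a limit of the assay, so the size of either change on that core stays unfixed: the limit of > 50000 nM in this assay, at which 1 of the 4 values shown sits.

The compounds shown carry only chloro and fluoro on the amide-side phenyl ring, which leaves open how a methoxy, a nitrile or a trifluoromethyl group would behave there. Going by these compounds, it also stays open whether an amine or a carboxylic acid on the other phenyl ring would change these numbers.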